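This account rests on a few compounds, and the source may have more. Where it says the series, first, only, none or still open, it means among the compounds named here.

Measured so far in a functional assay on CCRF-CEM cells (Homo sapiens), with a stated time of 72 h; on this read-out higher numbers stand for weaker inhibition and lower numbers for stronger inhibition:
compound 1 `O=C1Nc2ccc(Br)cc2/C1=N/NC(=S)Nc1ccc(Cl)cc1` gives 61000 nM;
compound 2 `Cc1ccc(CN2C(=O)/C(=N\NC(=S)Nc3ccc(Cl)cc3)c3cc(Cl)ccc32)cc1` gives 18000 nM;
compound 3 `O=C1/C(=N\NC(=S)Nc2ccc(Cl)cc2)c2cc(Br)ccc2N1Cc1ccc(F)cc1` gives 61000 nM.

Compound 3 stands level with compound 1 in this assay, the two together at the top of the three numbers, while compound 2 sits lower by more than the scatter. Going by the values given here, the only single-point step measured, no change at the digits printed from compound 1 to compound 3 (within the scatter), shows that adding the 4-fluorobenzyl group on the ring nitrogen left the number unchanged. Compound 4 `Cc1ccc(CN2C(=O)/C(=N\NC(=S)Nc3ccc(Cl)cc3)c3cc(Br)ccc32)cc1` differs from compound 3 by methyl in place of fluoro on an aromatic carbon. Among the compounds with values here, no measured step covers this exchange. Compound 2, which also carries the 4-methylbenzyl group, gives 18000 nM. A modest move downward, a 2.0-fold lower number from compound 3 to compound 4 (0.31 log units; beyond the scatter), is therefore expected, though it may stay within the scatter. Compound 4 is estimated at 30000 nM, range 12000 nM to 80000 nM.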

Compound 4, half-maximal inhibitory concentration: 98000 nM
Beside the measured number, compound 4's estimate is 3.3-fold (0.51 log units) below it, and the stated range ends below it.
By their numbers in this assay, from the lowest: compound 2; then compounds 1, 3 and 4 (each within the scatter of the next).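

In this assay, the change of 4-fluorobenzyl to 4-methylbenzyl gives a 1.6-fold higher number from compound 3 to compound 4 (0.21 log units; within the scatter) and so does not separate the two groups at this position. Placing 4-methylbenzyl on the ring nitrogen gives a 1.6-fold higher number from compound 1 to compound 4 (0.21 log units; within the scatter) in the same way as 4-fluorobenzyl did. Going by these compounds alone, the larger effect comes from the halogen on the core, where bromo in place of chloro gives a 5.4-fold higher number from compound 2 to compound 4 (0.74 log units; beyond the scatter) and is seen only with 4-methylbenzyl. On these data alone, whether chloro keeps its lower number with hydrogen or 4-fluorobenzyl on that nitrogen stays open, as does the effect of an amine or carboxylic acid in place of methyl. Nothing available explains these numbers.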